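Amidoxime series: benzyl to furan-2-ylmethyl on the amine

The compounds below may be only part of what the source reports. "The series", "measured", "known", "first", "only" and "open" are said of these compounds alone.

Measured so far:
- compound 1 `O/N=C(/Nc1cccc(F)c1)c1ccc2occc2c1`: 20000 nM
- compound 2 `O/N=C(/NCc1ccccc1)c1ccc2occc2c1`: 28200 nM

Both compounds are weak in an assay on tissue (HeLa cells) for inhibition of Indoleamine 2,3-dioxygenase 1 (Homo sapiens), read by spectrophotometry; a higher number here means a weaker inhibitor, a lower number a stronger inhibitor. Compound 1 gives 20000 nM in this assay, and compound 2 gives 28200 nM. Compound 2 holds the higher of the two numbers, but the gap to compound 1 falls within the usual scatter of repeats, so the two cannot be told apart on this evidence.

Compound 3 `O/N=C(/NCc1ccco1)c1ccc2occc2c1` has not yet been measured. It differs from compound 2 in one place: furan-2-yl in place of phenyl on a saturated chain carbon bound to an amine nitrogen. Within the data shown here, no measured pair shows what such a change does, so there is nothing to lean on beyond the two values in hand, which sit close together and give no direction.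

Expectation for compound 3: a step of about a 1.1-fold higher number from compound 2 to compound 3 (0.03 log units; within the scatter) is estimated, that is, no change beyond the scatter in this assay. The number for compound 3 is expected near 30000 nM, within a range of 10000 nM to 90000 nM. A reported limit rather than a number remains possible, since compound 2 already sits high.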

Compound 3, half-maximal inhibitory concentration: > 30000 nM
Compound 3: no number, only a limit; the forecaster's own chance of this, stated with the estimate: 20%; the middle value lies on the limit itself.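

In this assay compound 3 gives > 30000 nM as a limit of the assay and not a number. Furan-2-yl in place of phenyl on a saturated chain carbon bound to an amine nitrogen gives an at least 1.0-fold higher number from compound 2 to compound 3 (0.02 log units; that floor lies within the scatter) and is the first one-place change readable in this series: at this position, the swap from the six-membered carbon ring to the five-membered ring with one hetero atom brings no lower number in this assay. The step is a floor and not a size, so the change may be neutral or may be a real loss, and the reading stops at the ceiling of the assay: the limit of > 30000 nM in this assay, at which 1 of the 3 values shown sits.

From the compounds shown here alone, how far compound 3 lies past its limit stays open, so the true size of the step cannot be read. Also open, going by these compounds, is whether any other group at this position gives a lower number, for instance a longer chain carrying the phenyl, a pyridine ring in place of the phenyl, or a carboxylic acid on the phenyl.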